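Trading the Methyl Aryl for a Trifluoromethyl Aryl

The compounds below may be only part of what the source reports. "The series", "measured", "known", "first", "only" and "open" are said of these compounds alone.

Of the compounds shown here, three sharing a pyridinone amide core have been measured in a functional assay on MCF7 cells (Homo sapiens) for cytotoxicity, read by MTT assay, with a stated time of 72 h; a lower number here means a stronger inhibitor, a higher number a weaker inhibitor. Compound 1 `O=C(Nc1ccc(Oc2ccnc3[nH]ccc23)cc1)c1nn(-c2ccc(Cl)c(C(F)(F)F)c2)ccc1=O` gives 6270 nM. Compound 2 `Cc1ccc(-n2nc(C(=O)Nc3ccc(Oc4ncnc5[nH]ccc45)cc3)c(C)cc2=O)cc1` gives 3620 nM, and compound 3 `Cc1ccc(-n2nc(C(=O)Nc3ccc(Oc4ncnc5[nH]ccc45)c(F)c3)c(C)cc2=O)cc1` gives 18900 nM. Compound 3 therefore stands at the weakest end of the three, beyond the scatter from both neighbours. Among the compounds with values here, the single one-place step available runs a 5.2-fold higher number from compound 2 to compound 3 (0.72 log units; beyond the scatter), which shows that a fluoro added on the central aromatic ring cost potency.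

Compound 4 `Cc1cc(=O)n(-c2cccc(C(F)(F)F)c2)nc1C(=O)Nc1ccc(Oc2ncnc3[nH]ccc23)c(F)c1` is the next member, and it differs from compound 3 in one place: 3-(trifluoromethyl)phenyl in place of 4-methylphenyl on an aromatic nitrogen. Within the data shown here, no measured pair isolates this change. Compound 1 also carries a trifluoromethyl on its aryl group, but it differs from compound 3 at several other positions as well, so the value of compound 3 and the value of compound 1, 6270 nM, can only be set side by side, not read as a step. With nothing directly comparable, the step of a 1.6-fold lower number from compound 3 to compound 4 (0.20 log units; within the scatter) is expected to be small, perhaps a slight gain, and possibly within the scatter. On that basis compound 4 is estimated at 12000 nM, with a plausible range from 4000 nM to 40000 nM.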

Compound 4, half-maximal inhibitory concentration: 11800 nM
Beside the measured number, compound 4's estimate is 1.0-fold (0.01 log units) above it; low and high end bracket the measured number.
By their numbers in this assay, from the lowest: compounds 2, 1, 4 and 3 (each within the scatter of the next, the first and the last beyond it).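

Within the data shown here, the first reading at the aryl group on the aromatic nitrogen comes from the exchange of 4-methylphenyl for 3-(trifluoromethyl)phenyl, which in this assay gives a 1.6-fold lower number from compound 3 to compound 4 (0.20 log units; within the scatter). The earlier step concerned only a fluoro on the central aromatic ring, whereas this one shows that the aryl group on the nitrogen can be exchanged in this way with no difference that stands out from the scatter, at least with that fluoro in place and the rest of the structure unchanged. No available evidence bears on why these two aryl groups read alike.

The exchange alters both the substituent and its place on the aryl ring, so the compounds shown cannot separate the contribution of trifluoromethyl from that of its location, nor tell whether the result would hold without the fluoro on the central ring. Also open, on these data alone, is how this position would respond to an amine or a carboxylic acid on the aryl ring, since only methyl and trifluoromethyl can be compared here.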